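The compounds below may be only part of what the source reports. "The series", "measured", "known", "first", "only" and "open" are said of these compounds alone.

Working notes on the series. Compound 1 `O=C(Nc1cccc(-n2cc(-c3ccncc3)c(-c3ccc(Cl)c(O)c3)n2)c1)Nc1ccc(Cl)c(Cl)c1` carries the shared core with a 3,4-dichlorophenyl urea. In a functional assay on SW-620 cells (Homo sapiens) for inhibition, read by sulforhodamine B assay, with a stated time of 48 h (a lower number here means that less compound is tolerated, a higher number that more compound is tolerated), compound 1 reaches only a limit, > 32500 nM, so no number is known for it and it sits at the limit of > 32500 nM in this assay, at which 1 of the 2 values shown sits. Compound 2 `O=C(Nc1cccc(-n2cc(-c3ccncc3)c(-c3ccc(Cl)c(O)c3)n2)c1)Nc1cc(C(F)(F)F)cc(C(F)(F)F)c1` gives 23400 nM in this assay, a high value in the same region, so both measured members of the series are tolerated up to the top of the range tested. Compound 3 `O=C(Nc1cccc(-n2cc(-c3ccncc3)c(-c3ccc(Cl)c(O)c3)n2)c1)Nc1ccc(Cl)c(C(F)(F)F)c1` differs from compound 1 by trifluoromethyl in place of chloro on an aromatic carbon, the two values shown for compound 1 and compound 2 differing in substituents on the same ring with little visible effect on the number. Compound 3 is expected to behave in the same way, with a step of an at least 1.0-fold lower number from compound 1 to compound 3 (0.03 log units; that floor lies within the scatter) that stays within the usual scatter. Compound 3 is therefore estimated at 30000 nM, between 15000 nM and 60000 nM, with a fair chance that this assay again reports only a limit.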

Compound 3, concentration lethal to 50% of the cells: > 32500 nM
Compound 3: no number, only a limit (the forecaster's own chance of this, stated with the estimate: 50%); at least 1.0-fold (0.03 log units) between middle value and limit.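

Compound 1 and compound 3 both reach only a limit in this assay, so no step between them can be read: the limit of > 32500 nM in this assay, at which 2 of the 3 values shown sit.

Whether trifluoromethyl in place of chloro on an aromatic carbon changes the number at all remains open from the compounds shown.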